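The source may hold more compounds than are shown below. What is called first, only, known or untested is meant among the compounds shown, and "the series" means these compounds.

Compound 1 `N=C1S/C(=C\c2ccc(OCc3ccccc3)cc2)C(=O)N1c1ccc(Cl)cc1`: 16.4%
Compound 2 `N=C1S/C(=C\c2ccc(OCc3ccccc3)cc2)C(=O)N1c1ccc([N+](=O)[O-])cc1`: 17.3%

In an ADME assay on RAW264.7 cells (Mus musculus) for cytotoxicity, read by MTT assay, with a stated time of 48 h, tested at 50 uM (a higher number here means more inhibition at the concentration tested (going by the name of the read-out), a lower number less inhibition), compound 2 gives 17.3% and stands beside compound 1, whose value in this assay is 16.4%; the step of a number 0.9 percentage points higher from compound 1 to compound 2 (within the scatter) lies within the scatter. Compound 3 `N=C1S/C(=C\c2ccc(OCc3ccccc3)cc2)C(=O)N1c1ccccc1` differs from compound 2 by hydrogen in place of nitro on an aromatic carbon. Among the compounds with values here, the only measured step that bears on this change is a number 0.9 percentage points higher from compound 1 to compound 2 (within the scatter), where one group on that ring gave way to another with no movement beyond the scatter, so no step beyond the scatter is expected here either. Compound 3 is therefore expected to give about 15%, between 5% and 28%, an expected step of a number 2.3 percentage points lower from compound 2 to compound 3 (within the scatter).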

Compound 3, a percentage reported as inhibition, at one concentration (the size of the read-out at that concentration, not a potency): 37.9%
Estimate against measurement, compound 3: 22.9 percentage points below, outside the stated range (above it).
By their numbers in this assay, from the lowest: compounds 1 and 2 (each within the scatter of the next); then compound 3.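

In this assay hydrogen in place of nitro gives a number 20.6 percentage points higher from compound 2 to compound 3 (beyond the scatter) and hydrogen in place of chloro gives a number 21.5 percentage points higher from compound 1 to compound 3 (beyond the scatter) so this position is not indifferent to what it carries. The exchange of chloro for nitro had shown no such movement, and among these three compounds only the unsubstituted phenyl stands apart. Nothing measured here accounts for the rise.

The compounds shown leave open whether any group at this place would read like chloro and nitro, or whether a methyl, a methoxy, an amine or a carboxylic acid would fall nearer to hydrogen.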